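A few compounds are considered here, and "the series" means these few. Any claim that something is new, unique, unknown or untested is made for them only; others in the source may bear on it.

Measured compounds in a functional assay on BXPC-3 cells (Homo sapiens) for inhibition, read by MTT assay, with a stated time of 7 days; a lower number here means a stronger inhibitor, a higher number a weaker inhibitor:
- compound 1 `CCOC(=O)[C@@H]1CCC[C@H](S(=O)(=O)c2ccc(S(=O)(=O)N(CC)CC)cc2)C1` gives 25200 nM
- compound 2 `CCOC(=O)[C@@H]1CCCN(S(=O)(=O)c2ccc(S(=O)(=O)N3CCCCC3)cc2)C1` gives 3300 nM
- compound 3 `CCN(CC)S(=O)(=O)c1ccc(S(=O)(=O)N2CCC[C@@H](c3nc(C)no3)C2)cc1` gives 2900 nM

Compound 2 holds the second-highest of the three numbers. Its nearest neighbour is compound 3, whose number sits within the scatter of it, so no order between these two can be read. The one clear gap is to compound 1, which sits well above compound 2 and beyond the scatter; compound 1 differs from compound 2 in more than one place, so nothing about a single change can be drawn from that gap.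

Compound 4 `CCOC(=O)[C@@H]1CCCN(S(=O)(=O)c2ccc(S(=O)(=O)N(C)C)cc2)C1` is the next compound and differs from compound 2 in one place only: dimethylamino in place of piperidin-1-yl on a sulfonyl sulfur. Among the measured compounds shown here, no pair of measured compounds shows this change on its own, so there is no measured step to lean on. The change leaves the shared core untouched and trims the group on the sulfonyl sulfur. On the numbers shown, a modest move toward a weaker inhibitor is expected, of a size that may well stay within the scatter, as the step of a 1.5-fold higher number from compound 2 to compound 4 (0.18 log units; within the scatter) is meant to express.

Compound 4 is therefore estimated at 5000 nM in this assay, with a range from 2000 nM to 15000 nM.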

Compound 4, half-maximal inhibitory concentration: 1000 nM
The estimate for compound 4 lay 5.0-fold (0.70 log units) above the measured number; the whole stated range lies above it.
By their numbers in this assay, from the lowest: compound 4; then compounds 3 and 2 (each within the scatter of the next); then compound 1.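

Among the compounds shown here, the group on the sulfonyl sulfur proves to be a place where the read-out in this assay responds: with the shared core unchanged, dimethylamino in place of piperidin-1-yl gives a 3.3-fold lower number from compound 2 to compound 4 (0.52 log units; beyond the scatter), the first step that isolates a single change. In this pair, the ring of the piperidin-1-yl group is not needed to reach the lower number, since dimethylamino, with 3 heavy atoms against 6 and no ring, goes with the stronger inhibitor; this is one pair and makes no trend across the series. Nothing measured on hand accounts for the direction or size of this step.

A single step cannot show whether the number keeps falling as the group on the sulfonyl sulfur shrinks further, to methylamino or a plain amino group, or how other rings such as morpholin-4-yl or pyrrolidin-1-yl would compare with piperidin-1-yl. It also leaves open whether the same change would give a step of similar size elsewhere in the series, for instance with a carboxylic acid in place of the ethyl ester.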